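This account rests on a few compounds, and the source may have more. Where it says the series, first, only, none or still open, it means among the compounds named here.

Of the compounds shown here, three with a shared core have been measured in an assay on isolated protein for inhibition of Fatty-acid amide hydrolase 1 (Homo sapiens); on this read-out lower numbers stand for stronger inhibition and higher numbers for weaker inhibition. Compound 1 `O=C(CCCC1CCN(C(=O)c2ccccc2)CC1)c1ncco1` gives 77 nM, the lowest of the three numbers; compound 3 `CC(C)C(=O)N1CCC(CCCC(=O)c2ncco2)CC1` gives 250 nM, and compound 2 `O=C(CCCC1CCN(S(=O)(=O)Cc2ccccc2)CC1)c1ncco1` gives 600 nM. Compound 1 is therefore the strongest inhibitor among them, with both gaps beyond the scatter. The unmeasured compound 4 `CC(C)(C)CC(=O)N1CCC(CCCC(=O)c2ncco2)CC1` differs from compound 1 in one place: neopentyl in place of phenyl on a carbonyl carbon, a group with no ring in place of a ring; read one bond further out, benzoyl becomes neopentylcarbonyl. Going by the values given here, the only measured step that bears on this is the related exchange of phenyl for isopropyl, another group with no ring, which produced a 3.2-fold higher number from compound 1 to compound 3 (0.51 log units; beyond the scatter). Since compound 3 carries a group with no ring on the same carbonyl carbon and gives 250 nM, the expectation for compound 4 is a modest step upward in this assay, that is a somewhat weaker inhibitor than compound 1, roughly a 2.6-fold higher number from compound 1 to compound 4 (0.41 log units; beyond the scatter). Compound 4 is thus estimated at 200 nM, with a plausible range from 70 nM to 600 nM.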

Compound 4, half-maximal inhibitory concentration: 90 nM
Compound 4: middle estimate off by 2.2-fold (0.35 log units), on the high side, within the range that was stated.
By their numbers in this assay, from the lowest: compounds 1 and 4 (each within the scatter of the next); then compound 3; then compound 2.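

In this assay, on a carbonyl carbon whose other neighbour is an amide-type nitrogen in a ring, exchanging phenyl for neopentyl gives a 1.2-fold higher number from compound 1 to compound 4 (0.07 log units; within the scatter), so among these compounds a ring at this place is not required for a number level with that of compound 1. The two groups with no ring also differ from each other: neopentyl in place of isopropyl gives a 2.8-fold lower number from compound 3 to compound 4 (0.44 log units; beyond the scatter), so the absence of a ring alone cannot account for the higher number of compound 3. Nothing at hand explains why these two groups part ways.

Going by these compounds, it remains open how cyclohexyl, a ring of carbon only that is not aromatic, would compare with phenyl and neopentyl at this place. A longer chain such as hexyl, or neopentyl carrying an amine or a carboxylic acid, is equally untested by the compounds shown.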